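Swapping Fluoro for Methoxy on the Aryl Ring

This account rests on a few compounds, and the source may have more. Where it says the series, first, only, none or still open, it means among the compounds named here.

Compound 1, `COc1nc(-c2ccsc2)ccc1[C@@H](c1ccccc1)[C@@](O)(CCN(C)C)c1cccc2ccccc12`: in a toxicity assay on HeLa cells (Homo sapiens) for cytotoxicity (on this read-out higher numbers stand for lower toxicity in this test and lower numbers for higher toxicity in this test), compound 1 gives > 64 ug/mL, a limit of the assay.
Compound 2, `COc1nc(-c2ccc(F)cc2)ccc1[C@@H](c1ccccc1)[C@@](O)(CCN(C)C)c1cccc2ccccc12`: in this assay compound 2 gives > 64 ug/mL, also a limit of the assay.

Compound 2 thus stands at the upper edge of what this test reports: its value is a limit, not a number. Within the data shown here, the only other value shown sits at the same place, as the limit of > 64 ug/mL in this assay, at which 2 of the 2 values shown sit, states. Among the measured compounds shown here, the single measured step, a step that the two limits leave unreadable from compound 1 to compound 2, therefore has no readable size, both of its ends being limits.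

Compound 3, `COc1ccc(-c2ccc([C@@H](c3ccccc3)[C@@](O)(CCN(C)C)c3cccc4ccccc34)c(OC)n2)cc1`, differs from compound 2 by methoxy in place of fluoro on an aromatic carbon. For the measured compounds named here, no measured step with a readable size bears on this change, so nothing in the data points to a step beyond the scatter in either direction in this assay. The step from compound 2 to compound 3 is therefore estimated as a step that the limit leaves unreadable from compound 2 to compound 3, meaning essentially no change. Compound 3 is expected to give 80 ug/mL, within a range of 32 ug/mL to 200 ug/mL, and most probably the assay would again report only a limit.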

Compound 3, half-maximal cytotoxic concentration: > 64 ug/mL
Compound 3: only a limit was reported (the forecaster's own chance of this, stated with the estimate: 80%); the middle value is on the limit's open side.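

Compound 3 also gives only a limit in this assay, so neither its step from compound 2 nor its step from compound 1 can be read: the limit of > 64 ug/mL in this assay, at which 3 of the 3 values shown sit.

The compounds shown leave open how far the true values of compound 1, compound 2 and compound 3 lie beyond that limit, and whether methoxy in place of fluoro changes anything.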